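The compounds below may be only part of what the source reports. "The series", "measured", "known", "first", "only" and "open" are said of these compounds alone.

Compound 3 `C#CCN(c1nc(-c2ccc(C)cc2)no1)C1CCCCC1` was tested in an ADME assay on HepG2 cells (Homo sapiens) for cytotoxicity, read by MTT assay, with a stated time of 48 h (on this read-out lower numbers stand for higher toxicity in this test and higher numbers for lower toxicity in this test), where compound 3 gives 91.9 ug/mL. Compound 1 `C#CCOc1ccc(-c2noc(NC3CCCCC3)n2)cc1` gives 119 ug/mL in this assay, a number within the scatter of that of compound 3, so the two cannot be told apart on these data. Compound 2 `CC(=O)OC[C@H]1O[C@H](OC[C@@H](CN=[N+]=[N-])OC(C)=O)C=C[C@@H]1OC(C)=O` reaches only a limit in this assay, reported as > 200 ug/mL, and this is the limit of > 200 ug/mL in this assay, at which 1 of the 3 values shown sits. Compound 4 `C#CCN(c1nc(-c2ccc(F)cc2)no1)C1CCCCC1` has not yet been measured in this assay; it differs from compound 3 by fluoro in place of methyl on an aromatic carbon. Going by the values given here, with no measured step of this kind to go on, the expected step of a 1.1-fold higher number from compound 3 to compound 4 (0.04 log units; within the scatter) is small, not beyond the scatter in either direction. Compound 4 is accordingly estimated at 100 ug/mL in this assay, with a range from 50 ug/mL to 200 ug/mL.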

Compound 4, half-maximal cytotoxic concentration: 41.1 ug/mL
The estimate for compound 4 lay 2.4-fold (0.39 log units) above the measured number, outside the stated range (below it).
By their numbers in this assay, from the lowest: compound 4; then compounds 3 and 1 (each within the scatter of the next). At a limit, above all of these: compound 2.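

In this assay, going by these compounds alone, fluoro in place of methyl on this aromatic carbon, para to a large group, gives a 2.2-fold lower number from compound 3 to compound 4 (0.35 log units; beyond the scatter) and so shows that this single position can move the number beyond the scatter, which no earlier pair could show. Nothing measured here accounts for the step. Open, on these data alone, is whether a chloro, a methoxy or an amine at this place would move the number further or the other way, and whether the same change would give a similar step on another core.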